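Fluoro on the pyridyl ring in a benzimidazole acid series

The source may report more compounds than this note shows. Statements on the series, on what has been measured and on what is new or still open speak of the compounds shown alone.

Of the compounds shown here, two have a number so far. In a physicochemical assay for solubility, read by HPLC, measured as thermodynamic solubility, with a stated time of 4 h, at pH 6.8 (a lower number here means a less soluble compound, a higher number a more soluble compound), compound 2 `Cn1c(COc2cccc(C(=O)O)c2)nc2ccc(Oc3ccccn3)cc21` gives 62 ug/mL, the highest of the two values; compound 1 `Cn1c(COc2cccc(C(=O)O)c2)nc2ccc(Oc3ccc4c(c3)OCC4)nc21` gives 17 ug/mL in this assay, a lower value, and the gap between the two stands beyond the usual scatter. Among the measured compounds shown here, no pair that differs in a single place has yet been measured, so no single step is known.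

Compound 3 `Cn1c(COc2cccc(C(=O)O)c2)nc2ccc(Oc3ncccc3F)cc21` is the next compound for this assay. Its difference from compound 2 is fluoro in place of hydrogen on an aromatic carbon. The change is small in atom count and brings no donor or acceptor, so a step of small size, if any, is expected from it, leaning slightly downward rather than upward, as one possibility. The step of a 1.6-fold lower number from compound 2 to compound 3 (0.19 log units; within the scatter) is the expected outcome. On that basis compound 3 is estimated at 40 ug/mL in this assay, within a range from 15 ug/mL to 110 ug/mL.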

Compound 3, solubility: 7.1 ug/mL
Beside the measured number, compound 3's estimate is 5.6-fold (0.75 log units) above it; measured number outside the range, below it.
By their numbers in this assay, from the lowest: compound 3; then compound 1; then compound 2.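

In this assay, fluoro in place of hydrogen on an aromatic carbon gives an 8.7-fold lower number from compound 2 to compound 3 (0.94 log units; beyond the scatter), the first single-place step known in the series. This position, ortho to a large group and two atoms from the ring nitrogen, is therefore not a silent one for this read-out, although the entering group is a single heavy atom with no hydrogen-bond donors or acceptors. No measurement at hand bears on what lies behind this step.

Still open, going by these compounds, is whether the step belongs to fluoro itself or would also come with another small group on the same carbon, such as chloro, methyl or an amine. Also open, on these data alone, is whether fluoro on another carbon of the pyridin-2-yl ring gives a step of similar size.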